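This account rests on a few compounds, and the source may have more. Where it says the series, first, only, none or still open, it means among the compounds named here.

Compounds measured so far in a functional assay on V79 cells (Cricetulus griseus) for cytotoxicity, read by colony formation; on this read-out higher numbers stand for weaker inhibition and lower numbers for stronger inhibition:
- Compound 1 `NC1CCN(c2c(F)c(F)c3c(=O)c(C(=O)O)cn(C4CC4)c3c2F)C1`: 100 ug/mL
- Compound 2 `NC1CCN(c2c(F)c(F)c3c(=O)c(C(=O)O)cn(C4CC4)c3c2C(F)(F)F)C1`: 190 ug/mL

Not yet measured:
- Compound 3 `Cc1c(F)c(N2CCC(N)C2)c(F)c2c1c(=O)c(C(=O)O)cn2C1CC1`

Compound 1 has a single measured neighbour, compound 2, and the two lie within the scatter of each other. Compound 3 differs from compound 1 as follows: methyl in place of fluoro on an aromatic carbon. In short, compound 3 carries a methyl group where compound 1 carries a fluoro group. Among the compounds with values here, the only measured step that bears on this is the swap of a different fluoro for trifluoromethyl, so it is a loose guide. That step is a 1.9-fold higher number from compound 1 to compound 2 (0.28 log units; within the scatter), and on this evidence no shift beyond the scatter is expected in this assay. The expected step is a 1.2-fold higher number from compound 1 to compound 3 (0.06 log units; within the scatter). Compound 3 is estimated at 115 ug/mL, with an expected range from 50 ug/mL to 260 ug/mL.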

Compound 3, half-maximal inhibitory concentration: 11 ug/mL
Compound 3: middle estimate off by 10-fold (1.02 log units), on the high side, outside the stated range (below it).
By their numbers in this assay, from the lowest: compound 3; then compounds 1 and 2 (each within the scatter of the next).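

In this assay, methyl in place of this fluoro gives a 9.1-fold lower number from compound 1 to compound 3 (0.96 log units; beyond the scatter) and shows that this aromatic carbon, para to a fluoro group and meta to the 3-aminopyrrolidin-1-yl group, can move the read-out beyond the scatter. The earlier swap, a 1.9-fold higher number from compound 1 to compound 2 (0.28 log units; within the scatter), was made at a different fluoro and stayed within the scatter, so it gave no hint of this. Nothing at hand explains why exchanging one heavy atom for another matters so much here.

On these data alone, whether an ethyl group, a methoxy group or an amine on this same carbon would also give a lower number remains open. Also open, as far as these compounds go, is whether hydrogen there would keep the number of compound 1 or move it toward that of compound 3.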